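From Methylamino to Isopropylamino: An Unmeasured Step

This account rests on a few compounds, and the source may have more. Where it says the series, first, only, none or still open, it means among the compounds named here.

Compound 1 `CNc1nc(NCc2ccco2)nc2ccccc12` has no number to stand on: in an ADME assay on J774.A1 cells (Mus musculus) for inhibition, read by MTT assay, with a stated time of 72 h (a lower number here means that less compound is needed, a higher number that more compound is needed for the effect), compound 1 gives "not determined" (no result reported) as its entry. Compound 3 `CCNc1nc(NC)c2ccccc2n1` likewise shows "not determined" (no result reported) as its entry. Among the compounds with values here, the only figure comes from compound 2 `CNc1nc(NC2CCCC2)nc2ccccc12`, which reads 39000 nM in this assay as its result.

Compound 4 `CC(C)Nc1nc(NCc2ccco2)nc2ccccc12` awaits measurement. Within the data shown here, it carries isopropyl in place of methyl on a nitrogen on an aromatic ring as its one change from compound 1. Among the measured compounds shown here, no measured step guides this change, so no step beyond the usual scatter is expected in either direction. For the measured compounds named here, the expectation rests on compound 2 with 39000 nM as the sole number available. For compound 4 the estimated half-maximal effective concentration is 30000 nM with an expected range from 10000 nM to 90000 nM in this assay.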

Compound 4, half-maximal effective concentration: 8300 nM
The estimate for compound 4 lay 3.6-fold (0.56 log units) above the measured number; the whole stated range lies above it.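

Compound 1 has no single number to set against compound 4, so no step can be read between them. The compounds shown leave open what methylamino to isopropylamino does here, and nothing available bears on a cause for the result.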